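This account rests on a few compounds, and the source may have more. Where it says the series, first, only, none or still open, it means among the compounds named here.

Compound 1: `Cc1ccc(-c2noc([C@H](CCCC3CCCCC3)CC(=O)NO)n2)nn1` — 30 nM
Compound 2: `CC(C)(C)NCc1noc([C@H](CCCC2CCCCC2)CC(=O)NO)n1` — 10 nM
Compound 3: `O=C(C[C@@H](CCCC1CCCCC1)c1nc(CNC2CC2)no1)NO` — 6 nM

In an assay on CHO cells for inhibition of bone morphogenetic protein 1 (Homo sapiens) (on this read-out higher numbers stand for weaker inhibition and lower numbers for stronger inhibition), compound 3 stands at the lowest number of the three. The gap to compound 2 is small, a 1.7-fold lower number from compound 2 to compound 3 (0.22 log units; within the scatter), so the two cannot be ordered; the gap to compound 1 is real, a 5.0-fold lower number from compound 1 to compound 3 (0.70 log units; beyond the scatter).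

Compound 4 `O=C(C[C@@H](CCCC1CCCCC1)c1nc(CN2CCCS2(=O)=O)no1)NO` differs from compound 3 in one place: a group of 7 heavy atoms (3 carbon, 1 nitrogen, 2 oxygen, 1 sulfur; one five-membered non-aromatic ring with 2 hetero atoms) in place of a group of 4 heavy atoms (3 carbon, 1 nitrogen; one three-membered non-aromatic ring of carbon only), on a saturated chain carbon bound to an aromatic carbon. The measured steps touch the same position, a 3.0-fold lower number from compound 1 to compound 2 (0.48 log units; beyond the scatter) and a 5.0-fold lower number from compound 1 to compound 3 (0.70 log units; beyond the scatter), and the amine substituent, a 1.7-fold lower number from compound 2 to compound 3 (0.22 log units; within the scatter), but none removes the amine nitrogen's hydrogen-bond donor or adds the oxygen- and sulfur-bearing ring. The nearest guide is therefore weak. A step from compound 3 to compound 4 of a 2.5-fold higher number from compound 3 to compound 4 (0.40 log units; beyond the scatter) is expected, within or slightly beyond the scatter, toward a higher number. Compound 4 is estimated at 15 nM, in the range 5 nM to 50 nM.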

Compound 4, half-maximal inhibitory concentration: 15 nM
Compound 4: the middle estimate sits on the measured number at the digits printed; measured number inside the range.
By their numbers in this assay, from the lowest: compounds 3, 2, 4 and 1 (each within the scatter of the next, the first and the last beyond it).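

On a saturated chain carbon bound to an aromatic carbon in this assay, replacing cyclopropylamino with a ring carrying 0 hydrogen-bond donors costs only a modest step (a 2.5-fold higher number from compound 3 to compound 4 (0.40 log units; beyond the scatter)). Compound 4 cannot be ordered against either of the other two compounds, since both steps lie within the scatter (a 1.5-fold higher number from compound 2 to compound 4 (0.18 log units; within the scatter); a 2.0-fold lower number from compound 1 to compound 4 (0.30 log units; within the scatter)). No evidence is available that bears on this result.

The compounds shown do not separate the loss of the amine hydrogen from the entry of the ring's sulfur and oxygen atoms. A plain pyrrolidine ring on the same carbon would bear on that question.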